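A few compounds are considered here, and "the series" means these few. Any claim that something is new, unique, unknown or untested is made for them only; others in the source may bear on it.

In a functional assay on HT-29 cells (Homo sapiens) for cytotoxicity, read by MTT assay, with a stated time of 6 days (on this read-out lower numbers stand for an effect already at smaller amounts and higher numbers for an effect only at larger amounts of compound), compound 1 `O=c1cc(-c2ccc([N+](=O)[O-])cc2)oc2cc(O)ccc12` gives 6.95 ug/mL. Among the measured compounds shown here, only one other compound has a number here: compound 2 `O=c1cc(-c2ccc([N+](=O)[O-])cc2)oc2c(O)c(O)ccc12` gives 3.46 ug/mL, and the two values lie within the scatter of each other. Compound 3 `COc1cc(-c2cc(=O)c3c(O)cccc3o2)cc(OC)c1O` gives > 25 ug/mL, which is a limit of the assay and not a number.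

Compound 4 `CC(C)(C)[Si](C)(C)Oc1ccc(-c2cc(=O)c3ccc(O)cc3o2)cc1` is the next to be tested, and the step from compound 1 replaces the nitro group on the aromatic carbon: a group of 8 heavy atoms (6 carbon, 1 oxygen, 1 silicon; no ring) in place of a group of 3 heavy atoms (1 nitrogen, 2 oxygen; no ring), on an aromatic carbon. The new group sits on the same six-membered aromatic ring of carbon only, para to a large group.

For the measured compounds named here, the only measured step, a 2.0-fold lower number from compound 1 to compound 2 (0.30 log units; within the scatter), lies within the scatter and places a hydroxy on the shared core rather than at this site, so it offers no direct guide to the size of this change. Going by the values given here, compound 3 also lacks the nitro group, and the limit of > 25 ug/mL in this assay, at which 1 of the 3 values shown sits, is the only evidence for a compound of that kind. It differs from compound 4 in other places as well, so it gives only a weak hint towards a higher number in this assay.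

The expected change is small and upward, estimated as a 1.4-fold higher number from compound 1 to compound 4 (0.16 log units; within the scatter), with nothing firmly expected beyond the scatter. For compound 4 the estimate is 10 ug/mL, with an expected range from 3.5 ug/mL to 30 ug/mL.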

Compound 4, concentration for half-maximal effect: 3.61 ug/mL
Compound 4: middle estimate off by 2.8-fold (0.44 log units), on the high side, within the range that was stated.
By their numbers in this assay, from the lowest: compounds 2, 4 and 1 (each within the scatter of the next). At a limit, above all of these: compound 3.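

The step shows that the site on the six-membered aromatic ring of carbon only accepts a much larger group in place of nitro, with no change beyond the scatter in this assay: the group of 8 heavy atoms gives a 1.9-fold lower number from compound 1 to compound 4 (0.28 log units; within the scatter). Among the compounds shown here, the earlier step, a 2.0-fold lower number from compound 1 to compound 2 (0.30 log units; within the scatter), placed a hydroxy on the shared core and said nothing about this site, so compound 4 gives the first reading here and shows that a measured number in this range does not depend on the nitro group. Compound 3 also lacks the nitro group but differs in other places, and its reading is a limit and not a number, so it remains the only such case: the limit of > 25 ug/mL in this assay, at which 1 of the 4 values shown sits.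

One replacement at this site cannot show which feature of the entering group, if any, matters for the number, since nitro and the group of 8 heavy atoms share no part beyond their place on the ring. From the compounds shown here alone, how an amine or a carboxylic acid would read on this aromatic carbon remains open, as does the effect of the entering group on the core of compound 2.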